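The compounds below may be only part of what the source reports. "The series", "measured", "known", "first", "only" and "open" are said of these compounds alone.

Two compounds have been measured in a functional assay on MCF7 cells (Homo sapiens) for cytotoxicity, read by MTT assay, with a stated time of 48 h; a higher number here means a weaker inhibitor, a lower number a stronger inhibitor:
compound 1 `CCCCCCCCNC(=O)[C@@H](NC(=O)/C=C/c1ccccc1)[C@@H](C)O` gives 35100 nM in this assay;
compound 2 `CCCCCCCCCCCCCCCCCCNC(=O)[C@@H](NC(=O)c1cccs1)[C@@H](C)O` gives 25700 nM in this assay.

Compound 2 has the lower of the two numbers, but compound 1 sits so close that the gap between them lies within the scatter of repeated measurements, so the two cannot be told apart, and both are weak inhibitors. Compound 1 and compound 2 differ from each other in more than one place, so their two values alone do not show which part of the structure matters.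

Compound 3 `CCCCCCCCCCCCCCCCCCNC(=O)[C@@H](NC(=O)/C=C/c1ccccc1)[C@@H](C)O` has not yet been measured. It is compound 2 with one change: 2-phenylethenyl in place of thiophen-2-yl on a carbonyl carbon. Compound 1 already carries the 2-phenylethenyl group and gives a value within the scatter of compound 2, which gives no reason to expect the change to move the number beyond the scatter in either direction. The step from compound 2 is therefore expected to be small, a 1.1-fold higher number from compound 2 to compound 3 (0.04 log units; within the scatter). For compound 3 the expected value in this assay is 28000 nM, with a likely range from 12000 nM to 70000 nM.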

Compound 3, half-maximal inhibitory concentration: 39200 nM
Beside the measured number, compound 3's estimate is 1.4-fold (0.15 log units) below it, and the stated range covers the measured number.
By their numbers in this assay, from the lowest: compounds 2, 1 and 3 (each within the scatter of the next).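

At the carbonyl carbon whose other neighbour is an amide-type nitrogen, 2-phenylethenyl in place of thiophen-2-yl can now be read as a single change, and in this assay it gives a 1.5-fold higher number from compound 2 to compound 3 (0.18 log units; within the scatter). For the compounds shown here, compound 3 also isolates the chain for the first time: decyl in place of hydrogen on a saturated chain carbon, eight bonds along the chain from an amide-type nitrogen, gives a 1.1-fold higher number from compound 1 to compound 3 (0.05 log units; within the scatter), so neither single change separates its pair of compounds in this assay. No measurement available here explains these results.

The compounds shown leave open whether another group on that carbonyl carbon, such as a plain phenyl ring or a group carrying an amine or a carboxylic acid, would give a number beyond the scatter of these three. Going by these compounds alone, they also leave open whether a chain much shorter than the one in compound 1, such as butyl, would do so in this assay.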